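This account rests on a few compounds, and the source may have more. Where it says the series, first, only, none or still open, it means among the compounds named here.

For the measured compounds named here, compound 2 `C=C(C)C(CCC/C=C(\c1ccccc1)c1cccnc1)C(=O)O` gives 28 nM in an assay (Equus caballus) for inhibition of Thromboxane-A synthase (Homo sapiens), using microsomes (on this read-out lower numbers stand for stronger inhibition and higher numbers for weaker inhibition), and stands lowest of the two numbers measured so far; the nearest is compound 1 `CSC(CCC/C=C(\c1ccccc1)c1cccnc1)C(=O)O`, which in this assay gives 30 nM, a gap within the scatter. Going by the values given here, the one measured step, a 1.1-fold lower number from compound 1 to compound 2 (0.03 log units; within the scatter), concerns the saturated chain carbon bound to the carbonyl carbon and changes nothing beyond the scatter.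

Compound 3 `CCOC(=O)CCCC/C=C(\c1ccccc1)c1cccnc1` is not yet measured. It differs from compound 2 by (ethoxycarbonyl)methyl in place of 1-carboxy-2-methylprop-2-en-1-yl on a saturated chain carbon, three bonds along the chain from a double-bonded chain carbon. This is a larger change than the measured step: the group that leaves carries the 1 hydrogen-bond donor of compound 2, and what enters has none, while the chain is also shortened. Among the compounds with values here, no measured step bears directly on removing the donor; the step from compound 1 to compound 2 only shows that exchanging the branch on that chain carbon left this assay unchanged within the scatter, and cannot predict the loss of the acid.

Given that, a weakening step is expected rather than none, with wide uncertainty: the expected step is a 7.1-fold higher number from compound 2 to compound 3 (0.85 log units; beyond the scatter), and compound 3 is estimated at 200 nM in this assay, within 40 nM to 1500 nM.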

Compound 3, half-maximal inhibitory concentration: 600 nM
Compound 3: middle estimate off by 3.0-fold (0.48 log units), on the low side, and the stated range covers the measured number.
By their numbers in this assay, from the lowest: compounds 2 and 1 (each within the scatter of the next); then compound 3.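

In this assay, for the compounds shown here, the saturated chain carbon, three bonds along the chain from a double-bonded chain carbon, proves sensitive to what it carries, which the exchange of branches in the earlier compounds did not show: (ethoxycarbonyl)methyl in place of 1-carboxy-2-methylprop-2-en-1-yl gives a large step (a 21-fold higher number from compound 2 to compound 3 (1.33 log units; beyond the scatter)), and the same group in place of carboxy(methylsulfanyl)methyl gives a large step as well (a 20-fold higher number from compound 1 to compound 3 (1.30 log units; beyond the scatter)). Both steps end at compound 3 and start from compounds that lie within the scatter of each other, so among the compounds shown, the position tolerates the change of branch while both carboxy-bearing groups hold up against the ester, and the hydrogen-bond donor count falls to 0 in that one change. Nothing measured here accounts for the size of these steps.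

Still open, as far as these compounds go, is whether the steps follow from the free carboxy group giving way to the ethyl ester or from the loss of the branch, as both change together in compound 3. A carboxylic acid on the unbranched chain, or an ethyl ester that keeps the methylsulfanyl branch, would separate the two.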